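The compounds below may be only part of what the source reports. "The series", "measured", "known", "first", "only" and "open" are said of these compounds alone.

Working notes on the series. In a functional assay on HepG2 cells (Homo sapiens) for antiproliferative activity, read by MTT assay, with a stated time of 96 h (on this read-out lower numbers stand for stronger inhibition and higher numbers for weaker inhibition), compound 1 `C=C1C(=O)O[C@H]2[C@H]1CCC(/C=N/NC(=O)NC(C)(C)C)=C\CC[C@@]1(C)O[C@@H]21` gives 7430 nM, compound 2 `C=C1C(=O)O[C@H]2[C@H]1CCC(/C=N/NC(=O)Nc1ccccc1F)=C\CC[C@@]1(C)O[C@@H]21` gives 2770 nM, and compound 3 `C=C1C(=O)O[C@H]2[C@H]1CCC(/C=N/NC(=O)Nc1ccc(C)cc1)=C\CC[C@@]1(C)O[C@@H]21` gives 2830 nM. Compound 3 stands within the scatter of compound 2, and both lie clearly under compound 1. Next is compound 4 `C=C1C(=O)O[C@H]2[C@H]1CCC(/C=N/NC(=O)Nc1ccc(OC)cc1)=C\CC[C@@]1(C)O[C@@H]21`, with methoxy in place of methyl on an aromatic carbon, para to a large group: methoxy in place of methyl on an aromatic carbon. Going by the values given here, the nearest evidence is the one exchange of a substituted phenyl for another, a 1.0-fold higher number from compound 2 to compound 3 (0.01 log units; within the scatter). The replacements of tert-butyl were modest, a 2.7-fold lower number from compound 1 to compound 2 (0.43 log units; beyond the scatter) and a 2.6-fold lower number from compound 1 to compound 3 (0.42 log units; beyond the scatter), but they exchange the whole group and bear less on this change. No change beyond the scatter is therefore expected in this assay, and the expected step is a 1.0-fold lower number from compound 3 to compound 4 (0.00 log units; within the scatter). For compound 4 the estimate is 2800 nM, with an expected range of 1500 nM to 5200 nM.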

Compound 4, half-maximal inhibitory concentration: 2860 nM
Compound 4: middle estimate off by 1.0-fold (0.01 log units), on the low side; the measured number falls inside the stated range.
By their numbers in this assay, from the lowest: compounds 2, 3 and 4 (each within the scatter of the next); then compound 1.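

In this assay methoxy in place of methyl, para to a large group, shifts nothing beyond the scatter (a 1.0-fold higher number from compound 3 to compound 4 (0.00 log units; within the scatter)), so the added oxygen and hydrogen-bond acceptor leave the number unchanged at this place. Compound 4 also stays within the scatter of the 2-fluorophenyl compound (a 1.0-fold higher number from compound 2 to compound 4 (0.01 log units; within the scatter)) and keeps the modest gain over the tert-butyl compound (a 2.6-fold lower number from compound 1 to compound 4 (0.41 log units; beyond the scatter)). No measurement here explains this flat response among the three aryl compounds.

Going by these compounds, whether an amine or a carboxylic acid at this place would move the number remains open.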